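This account rests on a few compounds, and the source may have more. Where it says the series, first, only, none or still open, it means among the compounds named here.

Measured so far:
- compound 1 `COc1ccc(NC(=O)Nc2cc(C)nc3ccccc23)cc1`: 787 10^-6 cm/s
- compound 2 `COc1ccc(NC(=O)Nc2cc(C)nc3ccccc23)cc1F`: 50 10^-6 cm/s
- compound 3 `Cc1cc(NC(=O)Nc2ccccc2[N+](=O)[O-])c2ccccc2n1`: 204 10^-6 cm/s

All three numbers come from an ADME assay for permeability, using PAMPA, at pH 7.4; a higher number here means that the compound crosses the layer faster, a lower number that the compound crosses the layer more slowly. Compound 1 gives the highest apparent permeability of the three; compound 3 sits nearest to it, and compound 2 furthest. Among the measured compounds shown here, the only single-point step among the measured compounds is a 16-fold lower number from compound 1 to compound 2 (1.20 log units; beyond the scatter), a large fall on adding fluoro on an aromatic carbon.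

The next compound is compound 4 `CCc1ccc(NC(=O)Nc2cc(C)nc3ccccc23)cc1`. Against compound 1 the change is ethyl in place of methoxy on an aromatic carbon. The group that leaves carries 1 hydrogen-bond acceptor, the group that enters 0; both have 2 heavy atoms and no ring, and the place is the same aromatic carbon of the six-membered ring of carbon only.

For the measured compounds named here, no measured step bears directly on this change: the step from compound 1 to compound 2 concerns fluoro in place of hydrogen at a different position, and compound 3 differs from compound 1 in more than one place. Compound 1 already stands at the top of the series, so in this assay the step from compound 1 to compound 4 is expected to be small, likely within the scatter, with no clear direction: a 1.0-fold higher number from compound 1 to compound 4 (0.01 log units; within the scatter). The estimate for compound 4 is 800 10^-6 cm/s, with a range from 350 10^-6 cm/s to 1600 10^-6 cm/s.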

Compound 4, apparent permeability: 535 10^-6 cm/s
Compound 4: middle estimate off by 1.5-fold (0.17 log units), on the high side, and the stated range covers the measured number.
By their numbers in this assay, from the lowest: compound 2; then compound 3; then compounds 4 and 1 (each within the scatter of the next).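

In this assay, ethyl in place of methoxy on this aromatic carbon, para to a large group, gives a 1.5-fold lower number from compound 1 to compound 4 (0.17 log units; within the scatter); the hydrogen-bond acceptor counted on methoxy is therefore not required at this place to keep the number within the scatter of compound 1. Among the compounds shown here, this is the first reading at this position, and it contrasts with the large step elsewhere on the same aromatic ring, a 16-fold lower number from compound 1 to compound 2 (1.20 log units; beyond the scatter), so within this small set, one single-point change stays within the scatter while the other goes well beyond it. No measurement available here gives a reason for the outcome of either change.

For the compounds shown here, the pair of compound 1 and compound 4 covers only two small groups of equal heavy-atom count, so it remains open whether an amine, a carboxylic acid or a longer chain such as butyl on this aromatic carbon would also stay within the scatter of compound 1. Also open, from the compounds shown here alone, is whether fluoro, added to compound 4 at the place it occupies in compound 2, would bring a fall of similar size.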